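Phenyl added to compound 2: cytotoxicity notes

The source may report more compounds than this note shows. Statements on the series, on what has been measured and on what is new or still open speak of the compounds shown alone.

Measured in an ADME assay on H9c2 cells (Rattus norvegicus) for cytotoxicity, read by resazurin assay, with a stated time of 72 h (a higher number here means that more compound is tolerated, a lower number that less compound is tolerated), as half-maximal cytotoxic concentration:
- compound 1 `C/C(=N\Nc1nc(CCl)cs1)c1ccc(Cl)c(Cl)c1` gives > 50000 nM as a limit
- compound 2 `C/C(=N\Nc1nc(-c2ccccc2)cs1)c1ccc(Cl)c(Cl)c1` gives > 50000 nM as a limit
- compound 3 `C/C(=N\Nc1nc(-c2ccccc2)c(C)s1)c1ccc(Cl)c(Cl)c1` gives > 50000 nM as a limit

Compound 2 gives > 50000 nM as a limit and not a number. The whole set shows the limit of > 50000 nM in this assay, at which 3 of the 3 values shown sit, and so no order among the compounds can be read.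

The change to compound 4 `C/C(=N\Nc1nc(-c2ccc(-c3ccccc3)cc2)cs1)c1ccc(Cl)c(Cl)c1` is phenyl in place of hydrogen on an aromatic carbon and puts phenyl in place of hydrogen on an aromatic carbon, para to a large group.

For the measured compounds named here, two measured steps bear on it. Going by the values given here, the first is a step that the two limits leave unreadable from compound 1 to compound 2 and brings in phenyl in place of chloromethyl on an aromatic carbon. The second is a step that the two limits leave unreadable from compound 2 to compound 3 and brings in methyl in place of hydrogen on an aromatic carbon. Neither gives a size to carry over. With compound 2 at > 50000 nM as a limit, no step beyond the scatter is expected in this assay and no direction can be given.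

For compound 4 the estimated value is 50000 nM with an expected range from 20000 nM to 100000 nM and a report as a limit is the likeliest outcome. The expected step is a number no higher from compound 2 to compound 4 (the limit leaves the size open) in this estimate.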

Compound 4, half-maximal cytotoxic concentration: > 50000 nM
Compound 4 was reported as a limit (the forecaster's own chance of this, stated with the estimate: 75%); the middle value lies on the limit itself.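

In this assay, compound 2 and compound 4 are both reported as limits and not numbers, so no step can be read between them and the added phenyl gets no size: the limit of > 50000 nM in this assay, at which 4 of the 4 values shown sit.

The compounds shown leave open whether any change on the shared core gives a measurable half-maximal cytotoxic concentration, and how compound 1, compound 2, compound 3 and compound 4 rank.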